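The source may report more compounds than this note shows. Statements on the series, on what has been measured and on what is new or still open speak of the compounds shown alone.

Among the measured compounds shown here, compound 1 `CCOC(=O)C1=Cc2ccccc2OC1(OCc1cn(-c2ccc(F)cc2)nn1)C(F)(F)F` is the one member of this set with a measured number: in a functional assay on A549 cells (Homo sapiens) for inhibition, read by MTT assay, with a stated time of 24 h (a higher number here means a weaker inhibitor, a lower number a stronger inhibitor), compound 1 gives 7300 nM. Compound 2 `O=C(O)C1=Cc2ccccc2OC1(OCc1cc(-c2ccc(F)cc2)no1)C(F)(F)F` reaches only the limit of the assay, giving > 150000 nM. Compound 3 `CCOC(=O)C1=Cc2ccccc2OC1(OCc1cc(-c2ccc(OC)cc2)no1)C(F)(F)F` likewise gives only a limit, > 150000 nM. So compound 1 stands alone on the numbers shown; the other two values belong to the limit of > 150000 nM in this assay, at which 2 of the 3 values shown sit. Compound 4 `CCOC(=O)C1=Cc2ccccc2OC1(OCc1cn(CC(=O)Nc2cccc(F)c2)nn1)C(F)(F)F` has not yet been measured; it differs from compound 1 in one place: ((3-fluorophenyl)carbamoyl)methyl in place of 4-fluorophenyl on an aromatic nitrogen. For the measured compounds named here, no measured pair in this set differs in a single place, so the size of such a change has not been seen here. The change is expected to shift potency only modestly, a 1.4-fold higher number from compound 1 to compound 4 (0.14 log units; within the scatter) in this assay, with no firm direction. Compound 4 is estimated at 10000 nM, in a range from 2000 nM to 50000 nM.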

Compound 4, half-maximal inhibitory concentration: > 150000 nM
Compound 4: no number, only a limit; the forecaster's own chance of this, stated with the estimate: 25%; at least 15-fold (1.17 log units) between middle value and limit.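

Among the compounds shown here, at this position the group on the aromatic nitrogen clearly matters: in this assay the change gives an at least 20-fold higher number from compound 1 to compound 4 (1.31 log units; beyond the scatter) and is the only single-place step seen so far. Compound 4 gives only a limit of the assay, so this step has a floor but no exact size: the limit of > 150000 nM in this assay, at which 3 of the 4 values shown sit.

The compounds shown leave open which part of the new group goes with the step, the carbamoyl link or the 3-fluorophenyl ring. A plain benzyl group or a 3-fluorophenyl group set directly on that nitrogen would help separate the two.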